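The source may hold more compounds than are shown below. What is called first, only, known or untested is meant among the compounds shown, and "the series" means these compounds.

Three compounds share one core. Compound 1 `CCC1CCCN(C(=O)CN2CN(c3ccccc3)C3(CCN(C(=O)c4ccc(C(C)(C)C)cc4)CC3)C2=O)C1` is the only one of them with a number: in an assay on HEK293 cells for displacement of a labelled ligand from NPC1-like intracellular cholesterol transporter 1 (Homo sapiens) (a lower number here means a stronger inhibitor, a higher number a weaker inhibitor), compound 1 gives 3900 nM. Compound 2 `CCc1nn(CC)c(C2CCN(C(=O)CN3CN(c4ccccc4)C4(CCN(C(=O)c5ccc(C6CCCCC6)cc5)CC4)C3=O)CC2)c1C` was also prepared, but in this assay compound 2 shows only "not determined" (no result reported), so compound 1 stands alone among the measured entries, and no step between two measured compounds can be drawn from what is shown.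

Compound 3 `CC(C)(C)c1ccc(C(=O)N2CCC3(CC2)C(=O)N(CC(=O)NCCCCCO)CN3c2ccccc2)cc1` has not yet been measured. It differs from compound 1 in a single place: (5-hydroxypentyl)amino in place of 3-ethylpiperidin-1-yl on a carbonyl carbon. A six-membered ring is thus exchanged for an open chain that ends in a hydroxyl, on the carbonyl carbon whose other neighbour is a saturated chain carbon.

Among the measured compounds shown here, with no comparable step on record, the direction of the change cannot be read from the data. A move beyond the usual scatter is possible in either direction, so the expected step of a 1.3-fold higher number from compound 1 to compound 3 (0.11 log units; within the scatter) is set close to no change, with a wide range around it. For compound 3 the expected value in this assay is 5000 nM, within a range from 1500 nM to 20000 nM.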

Compound 3, half-maximal inhibitory concentration: 9400 nM
Beside the measured number, compound 3's estimate is 1.9-fold (0.27 log units) below it; the range from low to high includes it.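

Swapping 3-ethylpiperidin-1-yl for (5-hydroxypentyl)amino on the carbonyl carbon gives a 2.4-fold higher number from compound 1 to compound 3 (0.38 log units; beyond the scatter) in this assay, the first step on record at this position. The group on this carbonyl carbon therefore does affect the result, yet the change is modest: an open chain ending in a hydroxyl, with no ring at all, still gives a measurable value, so the six-membered ring is not essential for activity in this assay. This single exchange removes the ring, adds the amide hydrogen and adds the hydroxyl all at once, and no supporting measurement is available to show which of these changes matters.

The compounds shown leave open whether the weaker result comes from losing the ring or from gaining the hydroxyl, a question that a plain pentylamino group or an unsubstituted piperidin-1-yl group on the same carbonyl carbon could help to separate. They also leave open how a longer chain, or a chain ending in a carboxylic acid or an amine instead of a hydroxyl, would behave at this position.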